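This account rests on a few compounds, and the source may have more. Where it says the series, first, only, none or still open, it means among the compounds named here.

Three amides on the shared core have been run in a functional assay on the whole organism (strain Wistar) for inhibition, with Rattus norvegicus as the target, read by paw edema, with stated times of 60 min and 24 h, at a dose of 100 mg/kg by the oral route; on this read-out higher numbers stand for more inhibition at the one dose given (going by the name of the read-out) and lower numbers for less inhibition. Compound 1 `COc1cc2c(cc1OC)C(CC(=O)N(C)C)CC2` gives 23.3%, compound 2 `CCNC(=O)CC1CCc2cc(OC)c(OC)cc21` gives 33.3%, and compound 3 `CCCNC(=O)CC1CCc2cc(OC)c(OC)cc21` gives 26.7%. Compound 2 holds the highest of the three numbers, yet a number 10 percentage points higher from compound 1 to compound 2 (within the scatter) and a number 6.6 percentage points lower from compound 2 to compound 3 (within the scatter) lie within the scatter, as does a number 3.4 percentage points higher from compound 1 to compound 3 (within the scatter), so no firm ordering follows. Compound 4 `COc1cc2c(cc1OC)C(CC(=O)NCc1ccccc1)CC2` differs from compound 2 by phenyl in place of methyl on a saturated chain carbon bound to an amide-type nitrogen, ethylamino becoming benzylamino. Among the measured compounds shown here, the closest precedent is compound 3, which also altered the chain on the amide-type nitrogen, and its change is expected to be a guide because a number 6.6 percentage points lower from compound 2 to compound 3 (within the scatter) stayed within the scatter. Compound 4 is therefore expected to show no step beyond the scatter, a number 3.3 percentage points lower from compound 2 to compound 4 (within the scatter). For compound 4 the inhibition is estimated at 30%, between 15% and 45%.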

Compound 4, a percentage reported as inhibition, in the whole organism at one dose (the size of the read-out at that dose, not a potency): 43.3%
Beside the measured number, compound 4's estimate is 13.3 percentage points below it; the measured number falls inside the stated range.
By their numbers in this assay, from the lowest: compounds 1, 3, 2 and 4 (each within the scatter of the next, the first and the last beyond it).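

In this assay, among the compounds shown here, the change on the saturated chain carbon bound to an amide-type nitrogen yields the first steps beyond the scatter, with a number 16.6 percentage points higher from compound 3 to compound 4 (beyond the scatter) and a number 20 percentage points higher from compound 1 to compound 4 (beyond the scatter) both modest. Against its closest neighbour the change stays unresolved, since a number 10 percentage points higher from compound 2 to compound 4 (within the scatter) leaves benzylamino and ethylamino inseparable. Nothing measured here explains these steps. The compounds shown leave open whether the ring itself matters, and how a phenethyl chain or a pyridylmethyl group in place of benzyl would read out.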